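Nitro to chloro swap on the benzyloxy ring

The compounds below may be only part of what the source reports. "The series", "measured", "known", "first", "only" and "open" are said of these compounds alone.

Measured compounds in an assay on isolated protein for inhibition of Amine oxidase [flavin-containing] B (Homo sapiens), read by Amplex Red, with a stated time of 15 min; on this read-out higher numbers stand for weaker inhibition and lower numbers for stronger inhibition:
compound 1 `CC(=O)c1ccc(OCc2ccccc2[N+](=O)[O-])cc1`: 284 nM
compound 2 `CC(=O)c1ccc(OCc2ccc([N+](=O)[O-])cc2)cc1`: 96.5 nM
compound 3 `CC(=O)c1ccc(OCc2ccccc2Cl)cc1`: 311 nM

Compound 1 and compound 2 share the same atoms joined differently; the difference between the two cores is not broken down here. Compound 2 gives the lowest of the three numbers, beyond the scatter from both others. The change chloro in place of nitro on an aromatic carbon gives a 1.1-fold higher number from compound 1 to compound 3 (0.04 log units; within the scatter).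

Compound 4 `CC(=O)c1ccc(OCc2ccc(Cl)cc2)cc1` is not yet measured. It carries the same kind of change, (chloro in place of nitro on an aromatic carbon), but the place differs: ortho to a large group in the first case, para to a large group here. The expected step of a 1.1-fold higher number from compound 2 to compound 4 (0.06 log units; within the scatter) is estimated small, resting on the flat step a 1.1-fold higher number from compound 1 to compound 3 (0.04 log units; within the scatter) seen for the ortho case. Compound 4 is expected at about 110 nM, estimated between 50 nM and 260 nM.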

Compound 4, half-maximal inhibitory concentration: 63.2 nM
Compound 4: middle estimate off by 1.7-fold (0.24 log units), on the high side, and the stated range covers the measured number.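

In this assay, chloro in place of nitro on an aromatic carbon, para to a large group, gives a 1.5-fold lower number from compound 2 to compound 4 (0.18 log units; within the scatter). Set beside the same change at the other place, the two steps do not differ: the same change on two cores in this assay, a 1.1-fold higher number (0.04 log units; within the scatter) from compound 1 to compound 3 and a 1.5-fold lower number (0.18 log units; within the scatter) from compound 2 to compound 4, 1.7-fold (0.22 log units) apart, within the scatter of two such steps So in this series the swap carries from one core to the other without a detectable difference, but this rests on two pairs, both with steps within the scatter, and it neither gives a cause nor shows that the result holds on any further core.

Still open, on these data alone, is how an amine or a carboxylic acid on the same aromatic carbon would compare with nitro and chloro. As far as these compounds go, a longer chain at that carbon also remains untested by these compounds.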